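Shifting a bromine: from compound 1 to compound 4

A few compounds are considered here, and "the series" means these few. Any claim that something is new, unique, unknown or untested is made for them only; others in the source may bear on it.

Measured so far:
compound 1, `S=C(N/N=C/c1ccc2ccccc2n1)Nc1ccc(Br)cc1`: 56800 nM
compound 2, `CN(C)C(=S)N/N=C/c1nc2ccccc2s1`: 2100 nM
compound 3, `CN(C)C(=S)N/N=C/c1ccc2cccnc2n1`: 970 nM

All three numbers come from a functional assay on HeLa cells (Homo sapiens) for antiproliferative activity, read by sulforhodamine B assay, with a stated time of 72 h; a higher number here means a weaker inhibitor, a lower number a stronger inhibitor. Compound 1 stands at the highest of the three numbers, and so is the weakest inhibitor of the group; both compound 2 and compound 3 sit beyond the usual scatter below it, so the gap is real and not noise. Compound 2 and compound 3 carry a different arrangement around the thiocarbonyl carbon and different ring systems, so no single change links either of them to compound 1, and their values only show that much stronger inhibition is reachable within this series.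

Compound 4, `S=C(N/N=C/c1ccc2ccccc2n1)Nc1ccccc1Br`, has not yet been measured in this assay. It differs from compound 1 in one place: 2-bromophenyl in place of 4-bromophenyl on an amide-type nitrogen. Among the measured compounds shown here, nothing among the measured compounds reports what moving a bromine within this ring does, so the expectation rests on compound 1 alone. The step from compound 1 to compound 4 is expected to be small, close to the scatter, with a slight lean toward a lower number: a 1.4-fold lower number from compound 1 to compound 4 (0.15 log units; within the scatter). Compound 4 is therefore estimated to give about 40000 nM, within a range from 10000 nM to 150000 nM.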

Compound 4, half-maximal inhibitory concentration: > 100000 nM
Compound 4 ended at the assay's limit (the forecaster's own chance of this, stated with the estimate: 10%); middle value at least 2.5-fold (0.39 log units) from the limit.
By their numbers in this assay, from the lowest: compound 3; then compound 2; then compound 1. At a limit, above all of these: compound 4.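

In this assay compound 4 gives > 100000 nM, which is a limit of the assay and not a measured number. The earlier compounds shown here said nothing about where the bromine sits on this ring, and now the swap of 2-bromophenyl in place of 4-bromophenyl on the amide-type nitrogen can be read as a floor: an at least 1.7-fold higher number from compound 1 to compound 4 (0.24 log units; that floor lies within the scatter). That floor does not establish a real loss of inhibition, but this change gives no sign of a gain, and the full size of the step stays hidden: the limit of > 100000 nM in this assay, at which 1 of the 4 values shown sits.

The compounds shown leave open whether the bromine itself contributes anything to inhibition, since none of them carries a plain phenyl ring on this nitrogen, and whether another group placed at the 2-position of the ring, such as a methoxy group, a chlorine atom or an amine, would behave as the bromine does. They also do not show whether a change elsewhere on the core of compound 1 would move the number further than any change on this ring.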